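Removing the triazole substituent: compound 2 to compound 3

The source may report more compounds than this note shows. Statements on the series, on what has been measured and on what is new or still open speak of the compounds shown alone.

Compound 2 `CCNC(=O)[C@H]1O[C@@H](n2cnc3c(NC)nc(-n4cc(CC5CCCC5)nn4)nc32)[C@H](O)[C@@H]1O` stands highest of the two numbers in an assay on CHO cells for displacement of a labelled ligand from adenosine receptor A3 (Homo sapiens) (a higher number here means a weaker inhibitor, a lower number a stronger inhibitor), where compound 2 gives 11.5 nM. Among the measured compounds shown here, its nearest neighbour is compound 1 `CCCCc1cn(-c2nc(NC)c3ncn([C@@H]4O[C@H](C(=O)NCC)[C@@H](O)[C@H]4O)c3n2)nn1`, which in this assay gives 5.6 nM; the one measured step, a 2.1-fold higher number from compound 1 to compound 2 (0.31 log units; beyond the scatter), covers that gap. Compound 3 `CCNC(=O)[C@H]1O[C@@H](n2cnc3c(NC)nc(-n4ccnn4)nc32)[C@H](O)[C@@H]1O` is not yet measured and differs from compound 2 by hydrogen in place of cyclopentylmethyl on an aromatic carbon. For the measured compounds named here, no measured step matches this change directly: the step from compound 1 to compound 2 exchanges one chain end for another on a saturated chain carbon, whereas here the whole cyclopentylmethyl group leaves and only hydrogen remains. That measured step was modest yet beyond the scatter, so the group at this place does move the number. With the group removed entirely, the step expected is an 8.7-fold higher number from compound 2 to compound 3 (0.94 log units; beyond the scatter), larger than the measured one and towards a higher number. Compound 3 is therefore estimated at 100 nM, within 20 nM to 500 nM.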

Compound 3, inhibition constant: 2.1 nM
Compound 3: the middle estimate sits 48-fold (1.68 log units) above what was measured; measured number below the stated range.
By their numbers in this assay, from the lowest: compound 3; then compound 1; then compound 2.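

Replacing cyclopentylmethyl with hydrogen on this aromatic carbon gives a 5.5-fold lower number from compound 2 to compound 3 (0.74 log units; beyond the scatter) in this assay, and replacing butyl with hydrogen gives a 2.7-fold lower number from compound 1 to compound 3 (0.43 log units; beyond the scatter). The earlier step only ranked two substituents against each other; these steps show that both butyl and cyclopentylmethyl give a higher number than the bare 1H-1,2,3-triazol-1-yl group, so a large carbon group is not needed here for a low number. Nothing available explains this order among the three compounds.

As far as these compounds go, with only two carbon substituents to set against hydrogen, it remains open whether a small group such as methyl, or one carrying a heteroatom such as hydroxymethyl or aminomethyl, would fall above or below hydrogen. Also open, from the compounds shown here alone, is whether the same order holds when the shared core is changed elsewhere.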